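This account rests on a few compounds, and the source may have more. Where it says the series, first, only, none or still open, it means among the compounds named here.

Measured compounds:
- compound 1 `COc1cc(-n2ncnc2-c2ccc(OC(C)C)cc2)cc(OC)c1OC` — 610 nM
- compound 2 `COc1cc(-c2ncnn2-c2ccc(F)cc2)cc(OC)c1OC` — > 10000 nM
- compound 3 `COc1cc(-c2ncnn2-c2ccc([N+](=O)[O-])cc2)cc(OC)c1OC` — > 10000 nM

Within the data shown here, in a functional assay on MCF7 cells (Homo sapiens) for antiproliferative activity, read by MTT assay, with a stated time of 72 h (a higher number here means a weaker inhibitor, a lower number a stronger inhibitor), compound 1 gives 610 nM, the only actual number in the set. Compound 2 reaches only a limit of this assay, > 10000 nM. Compound 3 likewise sits at a limit, > 10000 nM. Among the measured compounds shown here, the one single-point step, a step that the two limits leave unreadable from compound 2 to compound 3, is therefore unreadable, as both ends rest at the limit of > 10000 nM in this assay, at which 2 of the 3 values shown sit. For the measured compounds named here, compounds 2 and 3 differ from compound 1 in more than one place, so no step between them and compound 1 is counted.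

Compound 4 `COc1cc(-n2ncnc2-c2ccc(SC)cc2)cc(OC)c1OC` is not yet measured. Relative to compound 1 the change is methylsulfanyl in place of isopropoxy on an aromatic carbon. No measured step bears on this exchange; the only step shown is unreadable. Compound 4 is therefore expected to stay close to compound 1, with the step of a 1.5-fold lower number from compound 1 to compound 4 (0.18 log units; within the scatter) estimated as not beyond the usual scatter. The estimate for compound 4 in this assay is 400 nM, in the range 100 nM to 3000 nM.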

Compound 4, half-maximal inhibitory concentration: 390 nM
Compound 4: middle estimate off by 1.0-fold (0.01 log units), on the high side, and the stated range covers the measured number.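

In this assay, replacing isopropoxy with methylsulfanyl gives a 1.6-fold lower number from compound 1 to compound 4 (0.19 log units; within the scatter), so this position, on an aromatic carbon para to a large group, accepts a sulfur-linked group with fewer heavy atoms without a step beyond the scatter. Among these compounds, compound 4, at 390 nM, provides the second actual number in the set, and this is the first step that can be read. No measurement shown gives a cause for this result.

As far as these compounds go, how an amine, a carboxylic acid or a longer chain would read at this position in this assay stays open. Compound 2 and compound 3 both rest at a limit and differ from compound 1 in more than one place, so neither shows what fluoro or nitro would do at this position in the core of compound 1.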